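Swapping an oxygen-linked amine chain for a fluoropyridine

The source may report more compounds than this note shows. Statements on the series, on what has been measured and on what is new or still open speak of the compounds shown alone.

Among the measured compounds shown here, the three compounds measured so far share one core and differ only in the group on the para position of the pendant phenyl ring. Compound 1 `COc1cc(OC)c2c(=O)cc(-c3ccc(OC4CCN(C)CC4)cc3)oc2c1` gives 28% in a functional assay (Homo sapiens) for antiproliferative activity, read by resazurin assay, with a stated time of 48 h, tested at 5 uM; a lower number here means a weaker effect, a higher number a stronger effect of the compound at the concentration tested. Compound 2 `COc1cc(OC)c2c(=O)cc(-c3ccc(OC4CCNCC4)cc3)oc2c1` is reported as "not active" (no number reported) in this assay, so no number is available for it. Compound 3 `COc1cc(OC)c2c(=O)cc(-c3ccc(OCC(O)CN4CCCC4)cc3)oc2c1` gives 21% in this assay, and its number sits within the scatter of that of compound 1, the only other numbered entry; the step of a number 7 percentage points lower from compound 1 to compound 3 (within the scatter) confirms that these two are not told apart.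

Compound 4 `COc1cc(OC)c2c(=O)cc(-c3ccc(-c4ccc(F)nc4)cc3)oc2c1` carries a different kind of change: 6-fluoropyridin-3-yl in place of 2-hydroxy-3-(pyrrolidin-1-yl)propoxy on an aromatic carbon. For the measured compounds named here, the one measured step exchanged one oxygen-linked group for another and stayed within the scatter; no measured step removes the oxygen linker or attaches a ring directly, so nothing here speaks to the size or direction of the present step. The expectation is therefore an essentially unchanged read-out, a number 1 percentage points lower from compound 3 to compound 4 (within the scatter), with a wide range. Compound 4 is expected to give 20% in this assay, between 5% and 45%.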

Compound 4, a percentage reported as inhibition, at one concentration (the size of the read-out at that concentration, not a potency): "not active" (no number reported)
Compound 4 has no reported number here, so the estimate cannot be set against anything.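

Among the compounds shown here, compound 4 is reported in this assay as "not active" (no number reported), without a number, so no step from compound 3 to compound 4 can be read. Nothing shown offers an explanation for this result. From the compounds shown here alone, how far 6-fluoropyridin-3-yl truly shifts this read-out relative to 2-hydroxy-3-(pyrrolidin-1-yl)propoxy stays open.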